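The compounds below may be only part of what the source reports. "The series", "measured", "known", "first", "only" and "open" are said of these compounds alone.

Measured so far in an ADME assay on HepG2 cells (Homo sapiens) for cytotoxicity, read by luminescence, CellTiter-Glo and ATP content, with a stated time of 72 h; a lower number here means that less compound is needed, a higher number that more compound is needed for the effect:
compound 1, `COc1cccc(CNCCCNc2ccnc3cc(Oc4ccc(Cl)cc4)ccc23)c1O`, gives 5700 nM
compound 2, `COc1cccc(CNCCCNc2ccnc3cc(-c4ccc(C(F)(F)F)cc4)ccc23)c1O`, gives 2210 nM
compound 3, `COc1ccc(F)cc1CNCCCNc1ccnc2cc(-c3ccc(F)cc3)ccc12`, gives 770 nM

Compound 3 stands lowest of the three numbers; compound 2 is nearest and compound 1 furthest, both gaps beyond the scatter. Within the data shown here, the one measured step, a 2.6-fold lower number from compound 1 to compound 2 (0.41 log units; beyond the scatter), concerns the group on the aromatic carbon of the shared core and says nothing about the change considered now. Compound 4, `COc1cccc(CNCCCNc2ccnc3cc(-c4ccc(F)cc4)ccc23)c1O`, differs from compound 3 in one place: 2-hydroxy-3-methoxyphenyl in place of 5-fluoro-2-methoxyphenyl on a saturated chain carbon bound to an amine nitrogen. Among the measured compounds shown here, no measured step bears on this change. The 2-hydroxy-3-methoxybenzyl of compound 4 is also carried by compound 2, which gave 2210 nM. The step of a 1.7-fold higher number from compound 3 to compound 4 (0.23 log units; within the scatter) is therefore expected to be small, toward a higher number. Compound 4 is estimated at 1300 nM, within 450 nM to 4000 nM.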

Compound 4, half-maximal effective concentration: 6840 nM
Compound 4: the middle estimate sits 5.3-fold (0.72 log units) below what was measured, outside the stated range (above it).
By their numbers in this assay, from the lowest: compound 3; then compound 2; then compounds 1 and 4 (each within the scatter of the next).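

On the saturated chain carbon bound to an amine nitrogen, 2-hydroxy-3-methoxyphenyl in place of 5-fluoro-2-methoxyphenyl gives the largest step seen in this assay (an 8.9-fold higher number from compound 3 to compound 4 (0.95 log units; beyond the scatter)), so the number responds to this group. With that benzyl kept, fluoro in place of trifluoromethyl also moves the number (a 3.1-fold higher number from compound 2 to compound 4 (0.49 log units; beyond the scatter)), while 4-fluorophenyl in place of 4-chlorophenoxy stays within the scatter (a 1.2-fold higher number from compound 1 to compound 4 (0.08 log units; within the scatter)). Nothing available explains the step at the chain.

From the compounds shown here alone, the two rings differ in hydroxy, methoxy and fluoro at once, so which of these carries the step stays open. Going by these compounds, how a benzyl carrying only a hydroxy, or a nitrile, would read is also open.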